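The compounds below may be only part of what the source reports. "The series", "measured", "known", "first", "only" and "open" are said of these compounds alone.

Three compounds share a core in which a saturated ring fused to a benzene ring carries an acyl group on its nitrogen and an amide-bearing methylene on the benzene side. Compound 1 `CCC(=O)N1CCc2cc(CNC(=O)c3cccs3)ccc21` pairs a propanoyl group on the ring nitrogen with a thiophene carboxamide. Compound 2 `CCC(=O)NCc1ccc2c(c1)CCN2C(=O)c1ccccc1` reverses the roles, placing a benzoyl group on the nitrogen and a propanamide on the methylene. Compound 3 `CCCC(=O)NCc1ccc2c(c1)CCN2C(=O)CC(C)C` carries an isopentanoyl group on the nitrogen and a butanamide on the methylene.

In an assay on HEK293 cells for inhibition of Indoleamine 2,3-dioxygenase 1 (Homo sapiens), tested at 10 uM (a lower number here means less inhibition, a higher number more inhibition at the concentration tested (going by the name of the read-out)), compound 1 gives 89%, the highest of the three numbers. Compound 3 follows with 64%, a gap beyond the scatter, and compound 2 lies furthest back with 41%, also beyond the scatter. No pair among these three differs in only one place, so no single-change step can be read from them.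

Compound 4 `CC(C)C(=O)N1CCc2cc(CNC(=O)c3cccs3)ccc21` differs from compound 1 by one small change: methyl in place of hydrogen on a saturated chain carbon bound to a carbonyl carbon and a saturated chain carbon. Read one bond further out, propanoyl becomes isopropylcarbonyl. For the measured compounds named here, with no comparable step measured, the expectation for compound 4 rests on the small size of the change and on compound 1 giving 89%. The step is expected to be small, a number 7 percentage points lower from compound 1 to compound 4 (within the scatter), within the scatter or a little downward. Compound 4 is therefore estimated at 82%, with a likely range from 60% to 95%.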

Compound 4, a percentage reported as inhibition, at one concentration (the size of the read-out at that concentration, not a potency): 100%
Compound 4: the middle estimate sits 18 percentage points below what was measured; the measured number lies above the stated range.
By their numbers in this assay, from the lowest: compound 2; then compound 3; then compound 1; then compound 4.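

For the compounds shown here, this is the first step that changes a single place, so the effect of one change can be read directly: with the thiophene carboxamide part held constant, going from propanoyl to isopropylcarbonyl gives a number 11 percentage points higher from compound 1 to compound 4 (beyond the scatter) in this assay. The added methyl, on a saturated chain carbon bound to a carbonyl carbon and a saturated chain carbon, therefore does not cost any inhibition here, and this position accepts a branched chain at least as well as the straight one. This read-out is a percentage at one concentration rather than a potency. The step shows that the number rose, but not by how much the potency changed. No measurement here bears on what lies behind the rise.

The compounds shown leave open whether a longer chain such as butanoyl, or a ring such as cyclopropylcarbonyl, would hold the number at this position. They also leave open whether the same methyl step would act in the same way with the benzoyl or propanamide groups of compound 2, or with any group other than the thiophene carboxamide.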